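Amide substituent change from compound 3 to compound 4

The source may report more compounds than this note shows. Statements on the series, on what has been measured and on what is new or still open speak of the compounds shown alone.

The compounds share one core and differ in the group on the amide-type nitrogen. In an ADME assay on microsomes from liver (Mus musculus, strain CD-1) for metabolic stability, read by LC-MS, tested at 2 uM (a lower number here means that the compound disappears faster, a higher number that the compound lasts longer), compound 1 `CNC(=O)c1ccncc1Nc1cc(-c2ccc3ccn(C)c3c2)c2nccnc2c1` gives 0.45 h, compound 2 `CN1CCC(NC(=O)c2ccncc2Nc2cc(-c3ccc4ccn(C)c4c3)c3nccnc3c2)CC1=O` gives 0.717 h and compound 3 `CN1CC(NC(=O)c2ccncc2Nc2cc(-c3ccc4ccn(C)c4c3)c3nccnc3c2)CCC1=O` gives 0.75 h. Compound 3 therefore stands level with compound 2 and within the scatter of compound 1.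

Compound 4 `CN1CCC(CNC(=O)c2ccncc2Nc2cc(-c3ccc4ccn(C)c4c3)c3nccnc3c2)C1` carries (1-methylpyrrolidin-3-yl)methyl in place of 1-methyl-6-oxopiperidin-3-yl on an amide-type nitrogen. For the measured compounds named here, three measured steps bear on this change: a 1.6-fold higher number from compound 1 to compound 2 (0.20 log units; within the scatter), a 1.7-fold higher number from compound 1 to compound 3 (0.22 log units; within the scatter) and a 1.0-fold higher number from compound 2 to compound 3 (0.02 log units; within the scatter). All three changed the same amide substituent and stayed within the scatter. Going by the values given here, no measured compound carries the incoming group, so these steps offer only limited guidance. No change beyond the scatter is expected in this assay, and the expected step is a 1.3-fold lower number from compound 3 to compound 4 (0.10 log units; within the scatter). The estimate for compound 4 is 0.6 h, with an expected range from 0.3 h to 1.2 h.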

Compound 4, half-life: > 1 h
Compound 4 was reported as a limit; the forecaster's own chance of this, stated with the estimate: 3%; at least 1.6-fold (0.22 log units) between middle value and limit.
By their numbers in this assay, from the lowest: compounds 1, 2 and 3 (each within the scatter of the next). At a limit, above all of these: compound 4.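

Compound 4 gives > 1 h in this assay, which is a limit and not a number: the limit of > 1 h in this assay, at which 1 of the 4 values shown sits. For the compounds shown here, on the amide-type nitrogen, (1-methylpyrrolidin-3-yl)methyl in place of methyl gives the first step in these compounds that clears the scatter, an at least 2.2-fold higher number from compound 1 to compound 4 (0.34 log units; beyond the scatter). Against the two oxopiperidinyl groups the floors remain within the scatter, an at least 1.3-fold higher number from compound 3 to compound 4 (0.12 log units; that floor lies within the scatter) and an at least 1.3-fold higher number from compound 2 to compound 4 (0.14 log units; that floor lies within the scatter), so the data do not yet separate the incoming group from 1-methyl-6-oxopiperidin-3-yl or 1-methyl-2-oxopiperidin-4-yl.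

As far as these compounds go, how far the true half-life of compound 4 lies past its limit remains open. Also open, from the compounds shown here alone, is whether the result holds for a 1-methylpiperidin-4-yl group or a pyrrolidin-3-ylmethyl group without the ring methyl on the same amide-type nitrogen.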